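The source may report more compounds than this note shows. Statements on the series, on what has been measured and on what is new or still open speak of the compounds shown alone.

Compound 1, `C=CCc1cc(C(C)=O)c(O)cc1OCCCCCC#N`: 41%
Compound 2, `CC(=O)c1cc(C(C)(C)C)c(OCCCCCC(C)(C)C#N)cc1O`: 2%
Compound 3, `CCc1cc(C(C)=O)c(O)cc1OCCCC(C)(C)C(=O)O`: 43%

In an assay on isolated protein for binding affinity to leukotriene B4 receptor 1 (Homo sapiens), tested at 1 uM (a higher number here means more inhibition at the concentration tested (going by the name of the read-out), a lower number less inhibition), compound 1 stands second highest of the three numbers. Its value and that of compound 3 lie within the scatter of each other, so no order between them can be claimed; the value of compound 2 lies below both by more than the scatter.

Compound 4, `C=CCc1cc(C(C)=O)c(O)cc1OCCCCCC`, has not been measured in this assay. It differs from compound 1 by methyl in place of cyano on a saturated chain carbon, five bonds along the chain from an oxygen on an aromatic ring. Within the data shown here, no measured pair shows this change, so its effect is not known here. A step of the size a number 11 percentage points lower from compound 1 to compound 4 (beyond the scatter) from compound 1 to compound 4 is expected, downward but possibly within the scatter. For compound 4 a value of 30% is estimated, within a range from 8% to 55%.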

Compound 4, a percentage reported as inhibition, at one concentration (the size of the read-out at that concentration, not a potency): 9%
The estimate for compound 4 lay 21 percentage points above the measured number; low and high end bracket the measured number.
By their numbers in this assay, from the lowest: compounds 2 and 4 (each within the scatter of the next); then compounds 1 and 3 (each within the scatter of the next).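

In this assay, among these compounds, methyl in place of cyano on a saturated chain carbon, five bonds along the chain from an oxygen on an aromatic ring, gives a number 32 percentage points lower from compound 1 to compound 4 (beyond the scatter), the first single change that can be read here. It shows that the group at this place matters for the inhibition seen at the concentration tested. Nothing available explains the step. On these data alone, it remains open whether cyano is specifically required at this place, or whether a primary amide or an amine there would match compound 1.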